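The compounds below may be only part of what the source reports. "The series", "measured", "known", "first", "only" and "open" are said of these compounds alone.

Working notes on the series

Compound 3 `COc1ccc2c(=O)c(/C=C/C(=O)NCc3ccc(C)cc3)coc2c1` is one of three measured members of the shared core. In a functional assay on A549 cells (Homo sapiens) for inhibition, read by MTT assay, with a stated time of 48 h (on this read-out higher numbers stand for weaker inhibition and lower numbers for stronger inhibition), compound 3 gives only the limit > 100000 nM, so no number is known for it. Compound 1 `COc1ccc2c(=O)c(/C=C/C(=O)Nc3ccccc3)coc2c1` gives 51000 nM in this assay. Compound 2 `COc1ccc2c(=O)c(/C=C/C(=O)Nc3ccccc3OC)coc2c1` gives the limit > 100000 nM in this assay. Two of the three values sit at a limit (the limit of > 100000 nM in this assay, at which 2 of the 3 values shown sit), so the measured steps are floors only: an at least 1.9-fold higher number from compound 1 to compound 2 (0.29 log units; that floor lies within the scatter), and an at least 1.9-fold higher number from compound 1 to compound 3 (0.29 log units; that floor lies within the scatter); the step that the two limits leave unreadable from compound 2 to compound 3 cannot be read.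

Compound 4 `COc1ccc2c(=O)c(/C=C/C(=O)Nc3ccc(F)cc3)coc2c1` differs from compound 3 by 4-fluorophenyl in place of 4-methylbenzyl on an amide-type nitrogen. This reverses the direction of the step from compound 1 to compound 3, returning to an aryl group on the amide nitrogen as in compound 1, with fluorine added. Since the step of an at least 1.9-fold higher number from compound 1 to compound 3 (0.29 log units; that floor lies within the scatter) had a floor within the scatter, the expected step of an at least 1.6-fold lower number from compound 3 to compound 4 (0.22 log units; that floor lies within the scatter) is a return toward the value of compound 1, with no clear size beyond the scatter. Compound 4 is therefore estimated at 60000 nM in this assay, within 25000 nM to 150000 nM, with a real chance that only a limit is reported.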

Compound 4, half-maximal inhibitory concentration: 26800 nM
Compound 4: the middle estimate sits 2.2-fold (0.35 log units) above what was measured, and the stated range covers the measured number.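

In this assay, among the compounds shown here, 4-fluorophenyl on the amide-type nitrogen gives the first steps that are printed as beyond the scatter: an at least 3.7-fold lower number from compound 3 to compound 4 (0.57 log units; beyond the scatter), and an at least 3.7-fold lower number from compound 2 to compound 4 (0.57 log units; beyond the scatter). Fluoro in place of hydrogen on the aromatic carbon, by contrast, leaves the value unseparated from the unsubstituted phenyl: a 1.9-fold lower number from compound 1 to compound 4 (0.28 log units; within the scatter), so compound 1 and compound 4 cannot be ordered. The two larger steps are floors, not sizes, and rest on a limit: the limit of > 100000 nM in this assay, at which 2 of the 4 values shown sit.

The full sizes of those two steps and the step from compound 2 to compound 3 cannot be read. Going by these compounds, it remains open whether a plain benzyl group, a 4-aminophenyl group, a 4-carboxyphenyl group or a longer chain on the amide-type nitrogen would separate from compound 1 beyond the scatter.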